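The source may report more compounds than this note shows. Statements on the series, on what has been measured and on what is new or still open speak of the compounds shown alone.

Measured so far:
In an ADME assay for permeability, using PAMPA, with a stated time of 30 min, at pH 7.4 (on this read-out lower numbers stand for lower permeability and higher numbers for higher permeability), compound 1 `COc1ccc(F)cc1CNCCCNc1ccnc2cc(Cc3ccc(C#N)cc3)ccc12` gives 23 10^-6 cm/s.
In this assay compound 2 `COc1ccc(F)cc1CNCCCNc1ccnc2cc(Oc3ccc(F)cc3)ccc12` gives 317 10^-6 cm/s.
In this assay compound 3 `COc1cccc(CNCCCNc2ccnc3cc(Oc4ccc(F)cc4)ccc23)c1O` gives 317 10^-6 cm/s.

Compound 4 `COc1cccc(CNCCCNc2ccnc3cc(Cc4ccc(C#N)cc4)ccc23)c1O` has not yet been run in this assay. It differs from compound 3 by 4-cyanobenzyl in place of 4-fluorophenoxy on an aromatic carbon. The same change is seen between two measured compounds, (4-cyanobenzyl in place of 4-fluorophenoxy on an aromatic carbon), where it made a 14-fold lower number from compound 2 to compound 1 (1.14 log units; beyond the scatter). The two cores differ by 2-hydroxy-3-methoxyphenyl in place of 5-fluoro-2-methoxyphenyl on a saturated chain carbon bound to an amine nitrogen, a change that made no change at the digits printed from compound 2 to compound 3 (within the scatter), so compound 3 and compound 2 stand level, together the highest of the three numbers. The place line for both changes is the same word for word, so the change is regarded as the same change on two cores. Compound 4 is therefore expected to show a 14-fold lower number from compound 3 to compound 4 (1.14 log units; beyond the scatter), resting on compound 2 and compound 1 through a 14-fold lower number from compound 2 to compound 1 (1.14 log units; beyond the scatter) and on compound 3 through 317 10^-6 cm/s. For compound 4 the estimate in this assay is 23 10^-6 cm/s, between 8 10^-6 cm/s and 70 10^-6 cm/s.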

Compound 4, apparent permeability: 23 10^-6 cm/s
Compound 4: middle estimate and measured number agree at the digits printed; the measured number falls inside the stated range.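

In this assay, 4-cyanobenzyl in place of 4-fluorophenoxy on an aromatic carbon carries over to the second core, with a 14-fold lower number from compound 3 to compound 4 (1.14 log units; beyond the scatter), and the two readings agree: the same change on two cores in this assay, a 14-fold lower number (1.14 log units; beyond the scatter) from compound 2 to compound 1 and a 14-fold lower number (1.14 log units; beyond the scatter) from compound 3 to compound 4, 1.0-fold (0.00 log units) apart, within the scatter of two such steps. Likewise, 2-hydroxy-3-methoxyphenyl in place of 5-fluoro-2-methoxyphenyl carries over, with no change at the digits printed from compound 1 to compound 4 (within the scatter): the same change on two cores in this assay, no change at the digits printed (within the scatter) from compound 2 to compound 3 and no change at the digits printed (within the scatter) from compound 1 to compound 4, 1.0-fold (0.00 log units) apart, within the scatter of two such steps. This holds for these four compounds in this assay only; it shows that the two changes behave independently here, but it does not give a reason for the large step or show that it transfers to other cores.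

Open, going by these compounds, is how 4-cyanophenoxy or 4-fluorobenzyl on that aromatic carbon would read, which would separate the two parts of the change. Also open, on these data alone, is whether the step persists with a longer chain in the shared core.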